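The source may hold more compounds than are shown below. What is called first, only, known or untested is meant among the compounds shown, and "the series" means these compounds.

In an ADME assay on Vero cells (Chlorocebus sabaeus) for cytotoxicity, read by fluorescence, with a stated time of 4 days (a higher number here means a weaker inhibitor, a lower number a stronger inhibitor), compound 1 `COc1cc2c(cc1OC)CN(S(=O)(=O)c1ccc(-n3cc(COc4ccccc4C(C)=O)nn3)cc1)CC2` gives 37200 nM. Compound 2 `COc1cc2c(cc1OC)CN(S(=O)(=O)c1ccc(-n3cc(COc4ccc([N+](=O)[O-])cc4)nn3)cc1)CC2` gives only a limit, > 50000 nM. On these data alone, compound 3 `COc1cc2c(cc1OC)CN(S(=O)(=O)c1ccc(-n3cc(COc4ccccc4C)nn3)cc1)CC2` also gives only a limit, > 50000 nM, so its true position is unknown. Compound 4 `COc1cc2c(cc1OC)CN(S(=O)(=O)c1ccc(-n3cc(COc4cc(C=O)ccc4OC)nn3)cc1)CC2` differs from it by 5-formyl-2-methoxyphenyl in place of 2-methylphenyl on an oxygen on a saturated carbon. The nearest evidence is an at least 1.3-fold higher number from compound 1 to compound 3 (0.12 log units; that floor lies within the scatter), a floor within the scatter, together with an at least 1.3-fold higher number from compound 1 to compound 2 (0.12 log units; that floor lies within the scatter), also such a floor, and a step that the two limits leave unreadable from compound 2 to compound 3, which cannot be read. For the measured compounds named here, no measured step therefore exceeds the scatter, and none beyond the scatter is expected in this assay. The expected step is an at least 1.1-fold lower number from compound 3 to compound 4 (0.04 log units; that floor lies within the scatter). For compound 4 the estimate is 45000 nM, with an expected range of 20000 nM to 80000 nM.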

Compound 4, half-maximal inhibitory concentration: > 50000 nM
Compound 4: only a limit was reported; the forecaster's own chance of this, stated with the estimate: 50%; middle value at least 1.1-fold (0.04 log units) from the limit.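

In this assay compound 4 gives > 50000 nM, which is a limit. For the compounds shown here, the one readable step is an at least 1.3-fold higher number from compound 1 to compound 4 (0.12 log units; that floor lies within the scatter); the steps to compound 4 from the other two limits cannot be read. With 5-formyl-2-methoxyphenyl on this oxygen, a third aryl group now stands at the same reported limit as 4-nitrophenyl and 2-methylphenyl: the limit of > 50000 nM in this assay, at which 3 of the 4 values shown sit.

On these data alone, the order among compound 2, compound 3 and compound 4 stays open. So does whether a phenyl group carrying an amine or a carboxylic acid would give a measured value in this assay.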